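Amide replacement in the disulfonyl piperidine series

The source may hold more compounds than are shown below. What is called first, only, known or untested is meant among the compounds shown, and "the series" means these compounds.

Compound 3 `CCN(CC)S(=O)(=O)c1ccc(S(=O)(=O)N2CCC[C@@H](C(=O)N[C@H]3CC[C@@H](OC)CC3)C2)cc1` gives 960 nM in a functional assay on MIA PaCa-2 cells (Homo sapiens) for inhibition, read by MTT assay, with a stated time of 7 days; on this read-out lower numbers stand for stronger inhibition and higher numbers for weaker inhibition. Among the three compounds measured it holds the second highest number. Its nearest neighbour is compound 1 `CCN(CC)S(=O)(=O)c1ccc(S(=O)(=O)N2CCC[C@@H](C(=O)N[C@H]3CC[C@H](OC)CC3)C2)cc1`, which gives 1350 nM; the step of a 1.4-fold lower number from compound 1 to compound 3 (0.15 log units; within the scatter), with the fact that compounds 1 and 3 differ only in the configuration as drawn as the only difference between the two, does not separate them. The lowest number belongs to compound 2 `CCN(CC)S(=O)(=O)c1ccc(S(=O)(=O)N2CCC[C@@H](C(=O)N3CCC(OC)CC3)C2)cc1`, which gives 140 nM.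

Compound 4 `CCN(CC)S(=O)(=O)c1ccc(S(=O)(=O)N2CCC[C@@H](C(=O)N3CCS(=O)(=O)CC3)C2)cc1` differs from compound 3 in one place: 1,1-dioxothiomorpholin-4-yl in place of (4-methoxycyclohexyl)amino on a carbonyl carbon. Within the data shown here, two measured steps bear on this change. Both replace the same (4-methoxycyclohexyl)amino with a cyclic tertiary amide on the carbonyl carbon: a 9.6-fold lower number from compound 1 to compound 2 (0.98 log units; beyond the scatter) and, read in the opposite direction, a 6.9-fold higher number from compound 2 to compound 3 (0.84 log units; beyond the scatter). Both point the same way, towards a lower number once the amide hydrogen is gone. The entering 1,1-dioxothiomorpholin-4-yl is not the 4-methoxypiperidin-1-yl of compound 2, so the size carried over from those steps is uncertain, and the expected gain is set somewhat smaller than either of them. For compound 4 the expected step is a 3.2-fold lower number from compound 3 to compound 4 (0.51 log units; beyond the scatter), beyond the scatter. The estimate for compound 4 in this assay is 300 nM, with a range from 90 nM to 1000 nM.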

Compound 4, half-maximal inhibitory concentration: 900 nM
The estimate for compound 4 lay 3.0-fold (0.48 log units) below the measured number, within the range that was stated.
By their numbers in this assay, from the lowest: compound 2; then compounds 4, 3 and 1 (each within the scatter of the next).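

Taking away the amide hydrogen is not enough on its own at this carbonyl carbon: in this assay the change to 1,1-dioxothiomorpholin-4-yl gives a 1.1-fold lower number from compound 3 to compound 4 (0.03 log units; within the scatter) and a 1.5-fold lower number from compound 1 to compound 4 (0.18 log units; within the scatter), so compound 4 does not separate from either (4-methoxycyclohexyl)amino compound. The lower number seen for compound 2 therefore does not extend to every cyclic tertiary amide in this set, and compound 4 goes against that reading, with the two ring amides far apart: a 6.4-fold higher number from compound 2 to compound 4 (0.81 log units; beyond the scatter). The two (4-methoxycyclohexyl)amino compounds give one consistent comparison for this change, and they can be read together on a single ground: the fact that compounds 1 and 3 differ only in the configuration as drawn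

The compounds shown leave open whether the number of compound 2 follows its methoxy group or the piperidin-1-yl ring itself, and how an unsubstituted piperidin-1-yl or a morpholin-4-yl would read on this carbonyl carbon. They also offer no measured property that would explain the gap between 4-methoxypiperidin-1-yl and 1,1-dioxothiomorpholin-4-yl, so that gap stands here as an observation only.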